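A few compounds are considered here, and "the series" means these few. Any claim that something is new, unique, unknown or untested is made for them only; others in the source may bear on it.

Of the compounds shown here, three on a shared core have been measured in a functional assay on HEK293 cells for activation of melanin-concentrating hormone receptor 1 (Rattus norvegicus), read by inositol phosphate accumulation; a lower number here means that less compound is needed, a higher number that more compound is needed for the effect. Compound 1 `O=C(CCc1ccc(C(F)(F)F)cc1)Nc1ccc2nc(N3CCC(NS(=O)(=O)O)C3)ccc2c1` gives 50 nM, compound 2 `CN(C)c1ccc2cc(NC(=O)CCc3ccc(C(F)(F)F)cc3)ccc2n1` gives 110 nM, and compound 3 `CC(=O)NC1CCN(c2ccc3cc(NC(=O)CCc4ccc(C(F)(F)F)cc4)ccc3n2)C1` gives 440 nM. Compound 3 thus stands highest of the three numbers: the step of an 8.8-fold higher number from compound 1 to compound 3 (0.94 log units; beyond the scatter) is the larger gap and a 4.0-fold higher number from compound 2 to compound 3 (0.60 log units; beyond the scatter) the smaller one, while a 2.2-fold higher number from compound 1 to compound 2 (0.34 log units; beyond the scatter) separates the other two compounds.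

Compound 4 `NC1CCN(c2ccc3cc(NC(=O)CCc4ccc(C(F)(F)F)cc4)ccc3n2)C1` has not yet been measured. It differs from compound 3 in one place, (hydrogen in place of acetyl on an amine nitrogen), so that the 3-acetamidopyrrolidin-1-yl group becomes 3-aminopyrrolidin-1-yl. Of the measured steps, only an 8.8-fold higher number from compound 1 to compound 3 (0.94 log units; beyond the scatter) alters this same amine nitrogen, and it shows that the group on that nitrogen can move the number well beyond the scatter. The steps of a 2.2-fold higher number from compound 1 to compound 2 (0.34 log units; beyond the scatter) and a 4.0-fold higher number from compound 2 to compound 3 (0.60 log units; beyond the scatter) exchange the entire ring group and bear on the change only indirectly. Within the data shown here, no measured pair shows a bare hydrogen on that nitrogen, so the direction remains uncertain. Compound 1 gives 50 nM with sulfo on that nitrogen, and compound 3 gives 440 nM with acetyl. The free amine of compound 4 is expected to land between these, with an expected step of a 2.2-fold lower number from compound 3 to compound 4 (0.34 log units; beyond the scatter). Compound 4 is therefore estimated at 200 nM, within a range from 50 nM to 800 nM.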

Compound 4, half-maximal effective concentration: 200 nM
The estimate for compound 4 equals the measured number at the digits printed; the range from low to high includes it.
By their numbers in this assay, from the lowest: compound 1; then compounds 2 and 4 (each within the scatter of the next); then compound 3.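

In this assay, the acetyl group on this amine nitrogen proves dispensable: replacing it with hydrogen, the smallest possible change at this position, lowers the number (a 2.2-fold lower number from compound 3 to compound 4 (0.34 log units; beyond the scatter)). Replacing sulfo with hydrogen on the same nitrogen raises it (a 4.0-fold higher number from compound 1 to compound 4 (0.60 log units; beyond the scatter)), so the three groups now form a series at one position, with sulfo giving the lowest number, hydrogen the middle one and acetyl the highest. The 3-aminopyrrolidin-1-yl group also cannot be separated from dimethylamino on the aromatic carbon (a 1.8-fold higher number from compound 2 to compound 4 (0.26 log units; within the scatter)), which means that the pyrrolidine ring with a free amine and the small open dimethylamino group read alike here, unlike the acetylated ring.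

Nothing available explains why the group on this nitrogen moves the number. On these data alone, it also remains open whether a methanesulfonyl group, which keeps the sulfur but loses the acid oxygen, would stay near sulfo, and whether a methyl group or a longer acyl chain on the same nitrogen would fall within the span these three groups define.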